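Swapping the aryl group on the benzoxazolone core

This account rests on a few compounds, and the source may have more. Where it says the series, first, only, none or still open, it means among the compounds named here.

Compound 1 `O=C(NCCCCc1ccccc1)n1c(=O)oc2cc(-c3ccc(F)cc3)ccc21` is one of three carbamoyl benzoxazolones examined in an assay on HEK293 cells for inhibition of acid ceramidase (Homo sapiens), with a stated time of 10 min; a lower number here means a stronger inhibitor, a higher number a weaker inhibitor. In this assay compound 1 gives 79 nM, the higher of the two numbers recorded. Compound 3 `O=C(NCCCCc1ccccc1)n1c(=O)oc2c(Br)cccc21` gives 18 nM, and compound 2 `Cc1cccc2oc(=O)n(C(=O)NCCCCc3ccccc3)c12` gives no result reported. Compound 4 `O=C(c1ccc(Cl)cc1)c1ccc2c(c1)oc(=O)n2C(=O)NCCCCc1ccccc1` carries the same core and chain as compound 1 but differs at one aromatic carbon: (4-chlorophenyl)carbonyl in place of 4-fluorophenyl on an aromatic carbon. Within the data shown here, no measured pair shows this change, so its effect is unknown. The author expects the step from compound 1 to compound 4 to be small, a 1.3-fold lower number from compound 1 to compound 4 (0.12 log units; within the scatter), within or only slightly beyond the scatter and, if anything, toward a lower number. Compound 4 is thus estimated at 60 nM, with a range from 20 nM to 180 nM.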

Compound 4, half-maximal inhibitory concentration: 14 nM
Compound 4: the middle estimate sits 4.3-fold (0.63 log units) above what was measured; measured number outside the range, below it.
By their numbers in this assay, from the lowest: compounds 4 and 3 (each within the scatter of the next); then compound 1.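

In this assay, placing (4-chlorophenyl)carbonyl instead of 4-fluorophenyl on this aromatic carbon gives a 5.6-fold lower number from compound 1 to compound 4 (0.75 log units; beyond the scatter), so this position accepts a group that adds a carbonyl and a hydrogen-bond acceptor, and the number falls. The step changes the linking carbonyl and the halogen together, so it cannot show which of them matters. Nothing here bears on why the number fell. On these data alone, it remains open whether 4-chlorophenyl alone or (4-fluorophenyl)carbonyl would give a similar number. As far as these compounds go, an unsubstituted benzoyl group or an amine at this carbon is equally open.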